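From 3,4-dimethoxyphenyl to 2-methoxyphenyl on a shared core

This account rests on a few compounds, and the source may have more. Where it says the series, first, only, none or still open, it means among the compounds named here.

compound 1 (`COc1ccc(/C=C/C(=O)/C=C/c2ccc(OCc3cn(CCCCCOc4cc(=O)oc5ccccc45)nn3)c(OC)c2)cc1OC`) gives 45%
compound 2 (`COc1ccccc1/C=C/C(=O)/C=C/c1ccc(OCc2cn(CCCOc3cc(=O)oc4ccccc34)nn2)c(OC)c1`) gives 53%
compound 3 (`COc1cccc(/C=C/C(=O)/C=C/c2ccc(OCc3cn(CCCCOc4cc(=O)oc5ccccc45)nn3)c(OC)c2)c1`) gives 44%

All three numbers come from a functional assay on HCT-116 cells (Homo sapiens) for inhibition, read by sulforhodamine B assay, with a stated time of 48 h, tested at 50 uM (on this read-out lower numbers stand for less inhibition of growth and higher numbers for more inhibition of growth at the one concentration tested), and compound 1 stands within the usual scatter of both compound 2 and compound 3, so the three cannot be ranked. The step followed here leads to compound 4 (`COc1ccccc1/C=C/C(=O)/C=C/c1ccc(OCc2cn(CCCCCOc3cc(=O)oc4ccccc34)nn2)c(OC)c1`), which has not yet been measured. Compared with compound 1, it shows (2-methoxyphenyl in place of 3,4-dimethoxyphenyl on a double-bonded chain carbon bound to a double-bonded chain carbon), that is, 2-methoxyphenyl in place of 3,4-dimethoxyphenyl on a double-bonded chain carbon bound to a double-bonded chain carbon. Going by the values given here, no pair of measured compounds isolates this change. Compound 2 carries the same 2-methoxyphenyl and gives 53% in this assay, but it also differs from compound 4 elsewhere. No shift beyond the scatter is therefore expected in this assay. The expected step, a number 3 percentage points higher from compound 1 to compound 4 (within the scatter), stays within that scatter. For compound 4 the estimated value is 48%, with an expected range from 37% to 59% in this test.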

Compound 4, percent growth inhibition at one concentration: 33%
Estimate against measurement, compound 4: 15 percentage points above, outside the stated range (below it).
By their numbers in this assay, from the lowest: compound 4; then compounds 3, 1 and 2 (each within the scatter of the next).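

On the shared core with the pentyl-linked chain, replacing 3,4-dimethoxyphenyl with 2-methoxyphenyl on a double-bonded chain carbon bound to a double-bonded chain carbon gives a number 12 percentage points lower from compound 1 to compound 4 (beyond the scatter) in this assay. Going by these compounds alone, this is the first change at this position to be isolated, and it shows that growth inhibition responds to the aryl group there, which the three earlier compounds, all within the scatter of compound 1, could not show. Nothing measured here explains the drop.

A single step cannot separate the loss of one methoxy group from the new placement of the other. On these data alone, how a plain phenyl group or a carboxylic acid-bearing phenyl group would behave at this position remains open, as does whether the step holds with a shorter chain.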